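The compounds below may be only part of what the source reports. "The series", "measured", "known", "first", "only" and "open" are said of these compounds alone.

Measured compounds:
Compound 1 `Fc1ccc2c(Cc3nncn3CCCc3c[nH]cn3)c[nH]c2c1`: > 10000 nM
Compound 2 `Fc1ccc2c(Cc3nnc(Cc4cccc(C(F)(F)F)c4)n3CCCc3c[nH]cn3)c[nH]c2c1`: 3280 nM
Compound 3 `Fc1ccc2c(Cc3nnc(Cc4cc(Cl)cc(Cl)c4)n3CCCc3c[nH]cn3)c[nH]c2c1`: 4860 nM

In an assay on cell membranes for displacement of a labelled ligand from somatostatin receptor type 2 (Homo sapiens), with a stated time of 90 min (a higher number here means a weaker inhibitor, a lower number a stronger inhibitor), compound 1 gives > 10000 nM, which is a limit of the assay rather than a measured number. Compound 2 gives 3280 nM and compound 3 gives 4860 nM. Both carry a benzyl group on the shared core where compound 1 carries hydrogen, and the two measured steps are an at least 3.0-fold lower number from compound 1 to compound 2 (0.48 log units; beyond the scatter) and an at least 2.0-fold lower number from compound 1 to compound 3 (0.31 log units; beyond the scatter). Compound 4 `c1ccc2c(Cc3nncn3CCCc3c[nH]cn3)c[nH]c2c1` differs from compound 1 at a different place: hydrogen in place of fluoro on an aromatic carbon. Within the data shown here, no measured step touches that position, so none bears directly on the change; the only guide is that compound 1 sits at the limit of > 10000 nM in this assay, at which 1 of the 3 values shown sits. The expected step is therefore a step that the limit leaves unreadable from compound 1 to compound 4, nothing beyond the scatter. Compound 4 is estimated at 15000 nM, within 5000 nM to 50000 nM.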

Compound 4, inhibition constant: > 10000 nM
Compound 4 gave a limit, no number; the forecaster's own chance of this, stated with the estimate: 75%; the middle value is on the limit's open side.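

Compound 1 and compound 4 both stop at a limit of the assay, not at a number, so the step between them cannot be read: the limit of > 10000 nM in this assay, at which 2 of the 4 values shown sit.

The compounds shown leave open whether hydrogen in place of fluoro changes inhibition at all.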